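Dropping a fluoro group from a potent hit

The source may hold more compounds than are shown below. What is called first, only, known or untested is meant among the compounds shown, and "the series" means these compounds.

Of the compounds shown here, three sharing one core have been tested in a functional assay on T98G cells (Homo sapiens) for cytotoxicity, read by MTT assay, with a stated time of 48 h; a lower number here means a stronger inhibitor, a higher number a weaker inhibitor. Compound 1 `C/C(=N/NC(=S)Nc1ccccc1I)c1ccccn1` gives 8.09 nM. Compound 2 `CC(=NNC(=S)Nc1ccccc1F)c1ccccn1` gives 3.1 nM. Compound 3 `C/C(=N\NC(=S)Nc1ccc(Cl)cc1)c1ccccn1` gives 5.9 nM. Compound 2 sits with compound 3 inside the usual scatter of repeated measurements, so those two cannot be told apart, whereas the number for compound 1 lies beyond that scatter and higher than the number for compound 2.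

Compound 4 `CC(=NNC(=S)Nc1ccccc1)c1ccccn1` has not yet been measured in this assay. It differs from compound 2 in one place: hydrogen in place of fluoro on an aromatic carbon. Going by the values given here, no pair of measured compounds shows a change of this kind, so there is no measured step to lean on; what the data do show is that the three numbers so far lie close together despite different groups on the ring. On that basis no step beyond the scatter is expected, and the estimated step from compound 2 to compound 4 is a 1.6-fold higher number from compound 2 to compound 4 (0.21 log units; within the scatter). Compound 4 is expected to give 5 nM in this assay, with a range from 1.5 nM to 16 nM.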

Compound 4, half-maximal inhibitory concentration: 6.8 nM
Beside the measured number, compound 4's estimate is 1.4-fold (0.13 log units) below it, within the range that was stated.
By their numbers in this assay, from the lowest: compounds 2, 3, 4 and 1 (each within the scatter of the next, the first and the last beyond it).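

In this assay, the change from fluoro to hydrogen gives the first step measured at this position, a 2.2-fold higher number from compound 2 to compound 4 (0.34 log units; beyond the scatter), so the choice of group on this aromatic carbon, ortho to a large group, can shift the number by a modest amount beyond the scatter. The fluoro group is still not required for activity in the low range seen across this series, since compound 4, with only hydrogen there, gives 6.8 nM. Nothing measured here gives a reason for this step.

Going by these compounds, whether an amine, a methoxy group or a carboxylic acid on the same carbon would give a lower or higher number remains open. So does whether the step from fluoro to hydrogen would keep its size on a different core.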